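Removing a methyl group from a diaryl urea 5-lipoxygenase inhibitor

A few compounds are considered here, and "the series" means these few. Any claim that something is new, unique, unknown or untested is made for them only; others in the source may bear on it.

Measured compounds:
compound 1 `Cc1cc(OCc2nc3ccccc3s2)ccc1NC(=O)Nc1ccccc1` gives 730 nM;
compound 2 `Cc1cc(NC(=O)Nc2ccccc2)ccc1OCc1nc2ccccc2s1` gives 2070 nM.

In an assay on isolated protein for inhibition of Polyunsaturated fatty acid 5-lipoxygenase (Homo sapiens), read by HPLC, with a stated time of 10 min (a higher number here means a weaker inhibitor, a lower number a stronger inhibitor), compound 2 stands with the higher of the two numbers, and compound 1 gives the lower one, a gap beyond the usual scatter. Compound 3 `O=C(Nc1ccccc1)Nc1ccc(OCc2nc3ccccc3s2)cc1` keeps the shared core but differs in one place: hydrogen in place of methyl on an aromatic carbon, a hydrogen in place of methyl on an aromatic carbon. For the measured compounds named here, no measured pair shows this change alone, so nothing in the data fixes its size; a small shift, possibly none beyond the scatter, is expected. On that basis compound 3 is estimated at 1600 nM, between 600 nM and 4500 nM, an expected step of a 1.3-fold lower number from compound 2 to compound 3 (0.11 log units; within the scatter).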

Compound 3, half-maximal inhibitory concentration: 420 nM
Estimate against measurement, compound 3: 3.8-fold (0.58 log units) above, and the stated range ends above it.
By their numbers in this assay, from the lowest: compounds 3 and 1 (each within the scatter of the next); then compound 2.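

In this assay, swapping methyl for hydrogen on an aromatic carbon gives a 4.9-fold lower number from compound 2 to compound 3 (0.69 log units; beyond the scatter), so the methyl of compound 2 carries a real cost. The same swap gives a 1.7-fold lower number from compound 1 to compound 3 (0.24 log units; within the scatter), which stays within the scatter, so the methyl of compound 1 has no measurable effect and the outcome depends on where the methyl sits. Nothing shown here explains why the two steps differ. 

Going by these compounds, what an ethyl, a methoxy or a chlorine on this aromatic carbon would do remains open.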